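The source may report more compounds than this note shows. Statements on the series, on what has been measured and on what is new or still open speak of the compounds shown alone.

Compound 1 `c1cc(OCc2ccc3ccccc3n2)cc(OCc2nn[nH]n2)c1`: 140 nM
Compound 2 `c1ccc2nc(COc3ccc(CCc4nnn[nH]4)cc3)ccc2c1`: 280 nM

In a functional assay (Cavia porcellus) for inhibition of cysteinyl leukotriene receptor (Homo sapiens) (on this read-out lower numbers stand for stronger inhibition and higher numbers for weaker inhibition), compound 2 gives 280 nM, the higher of the two numbers. Compound 1 gives 140 nM, and the gap between the two lies within the scatter, so neither can be called the stronger inhibitor. Compound 3 `CCOC(=O)CCCOc1ccc(OCc2ccc3ccccc3n2)cc1` differs from compound 2 by 3-(ethoxycarbonyl)propoxy in place of 2-(1H-tetrazol-5-yl)ethyl on an aromatic carbon. Going by the values given here, no pair of measured compounds shows what such a change does, so the expectation rests on the change alone. A step of a 7.1-fold higher number from compound 2 to compound 3 (0.85 log units; beyond the scatter) toward weaker inhibition is expected. Compound 3 is estimated at 2000 nM, in a range from 400 nM to 10000 nM.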

Compound 3, half-maximal inhibitory concentration: 2000 nM
Compound 3: middle estimate and measured number agree at the digits printed; the measured number falls inside the stated range.
By their numbers in this assay, from the lowest: compounds 1 and 2 (each within the scatter of the next); then compound 3.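

Going by these compounds alone, putting 3-(ethoxycarbonyl)propoxy in place of 2-(1H-tetrazol-5-yl)ethyl in this assay gives a 7.1-fold higher number from compound 2 to compound 3 (0.85 log units; beyond the scatter) and is the only step here beyond the scatter, so the group at this place on the ring matters. Compound 3 still gives a measured number without a tetrazole ring, though inhibition is weaker. Nothing measured here explains the step.

The ring and the chain change together, so the step cannot be assigned to either one alone. As far as these compounds go, a carboxylic acid in place of the ethyl ester, or a tetrazole on the same propoxy chain, remains open.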